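Capping a Phenol Hydroxyl with a Methyl Group

A few compounds are considered here, and "the series" means these few. Any claim that something is new, unique, unknown or untested is made for them only; others in the source may bear on it.

Compound 1 `O=C(Nc1cccc(-n2cc(-c3ccncc3)c(-c3cc(O)cc(Cl)c3)n2)c1)Nc1ccc(Cl)c(C(F)(F)F)c1` was tested in a functional assay on M14 cells (Homo sapiens) for inhibition, read by sulforhodamine B assay, with a stated time of 48 h, tested at 0.1 uM (on this read-out lower numbers stand for a stronger effect and higher numbers for a weaker effect at the one concentration tested), where compound 1 gives 91%. Compound 2 `O=C(Nc1cccc(-n2cc(-c3ccncc3)c(-c3cc(O)cc(Cl)c3)n2)c1)Nc1ccc(Cl)c(Cl)c1` shares the whole framework and differs from compound 1 only by a chloro in place of trifluoromethyl on an aromatic carbon; in this assay compound 2 gives 93%. Among the measured compounds shown here, the only measured step, a number 2 percentage points higher from compound 1 to compound 2 (within the scatter), does not separate the pair: compound 1 stands at one end of the two numbers, but the gap to compound 2 is within the scatter, so neither can be called the more active.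

Compound 3 `COc1cc(Cl)cc(-c2nn(-c3cccc(NC(=O)Nc4ccc(Cl)c(C(F)(F)F)c4)c3)cc2-c2ccncc2)c1` is not yet measured. Relative to compound 1 it carries methyl in place of hydrogen on an oxygen on an aromatic ring, so that hydroxy becomes methoxy and 3-chloro-5-hydroxyphenyl becomes 3-chloro-5-methoxyphenyl. For the measured compounds named here, no measured step touches this oxygen; the one step available concerns a different place and was itself within the scatter. With nothing pointing either way, the expected step of a number 3 percentage points lower from compound 1 to compound 3 (within the scatter) is one that stays within the scatter. Compound 3 is therefore estimated at 88% in this assay, with a likely range from 72% to 100%.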

Compound 3, a percentage reported as activity, at one concentration (the size of the read-out at that concentration, not a potency): 96%
Estimate against measurement, compound 3: 8 percentage points below; the range from low to high includes it.
By their numbers in this assay, from the lowest: compounds 1, 2 and 3 (each within the scatter of the next).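

Among the compounds shown here, this is the first change at the oxygen of the 3-chloro-5-hydroxyphenyl ring, and in this assay the step of a number 5 percentage points higher from compound 1 to compound 3 (within the scatter) shows that methyl in place of hydrogen on this oxygen cannot be told apart from no change at all. At the one concentration tested, hydroxy and methoxy therefore read alike, so the hydrogen on this oxygen is not shown to matter here, and the position accepts one added carbon without a step beyond the scatter. Nothing available here bears on why the two compounds read alike. Together with the earlier step on the other ring, this means that neither of the two single changes seen so far moves the number beyond the scatter.

Still open, from the compounds shown here alone, is whether a group differing more from hydroxy, such as an amine, a carboxylic acid or a longer chain like ethoxy, would give a number that stands apart from compound 1. A reading at a single concentration also leaves open how these compounds would compare across a range of concentrations, where a difference between hydroxy and methoxy might or might not appear.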